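This account rests on a few compounds, and the source may have more. Where it says the series, first, only, none or still open, it means among the compounds named here.

Measured in a physicochemical assay for lipophilicity; a higher number here means a more lipophilic compound, a lower number a more polar compound:
compound 1 `O=C1CN(Cc2ccc(-c3ccc(F)c(CN4CCCCC4)n3)cc2)C(=O)N1CC1CC1`: 2.8
compound 2 `CCN1C(=O)CN(Cc2ccc(-c3cccc(CN4CCCCC4)n3)cc2)C1=O`: 1.7
compound 3 `O=C1CN(Cc2ccc(-c3cccc(CN4CCCCC4)n3)cc2)C(=O)N1C1CC1`: 1.6

In this assay compound 3 stands at 1.6, within the scatter of compound 2 and clearly under compound 1 at 2.8.

The next compound, compound 4 `CN1C(=O)CN(Cc2ccc(-c3cccc(CN4CCCCC4)n3)cc2)C1=O`, carries methyl in place of cyclopropyl on an amide-type nitrogen in a ring.

Among the measured compounds shown here, one measured step bears on this place: a number 0.10 log units lower from compound 2 to compound 3 (within the scatter), with cyclopropyl in place of ethyl on the same kind of nitrogen. Compound 1 differs from compound 3 in more than one place, so its gap says nothing about this nitrogen alone. For the measured compounds named here, no measured step covers methyl, so the expectation goes beyond the data and stays tentative. A small downward move in this assay is expected, a number 0.30 log units lower from compound 3 to compound 4 (within the scatter), hardly clear of the scatter. The estimate for compound 4 is 1.3, with an expected range of 1 to 1.6.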

Compound 4, distribution coefficient: 1.3
Compound 4: the middle estimate sits on the measured number at the digits printed; measured number inside the range.
By their numbers in this assay, from the lowest: compounds 4, 3 and 2 (each within the scatter of the next, the first and the last beyond it); then compound 1.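

With methyl, the amide-type nitrogen in a ring now carries three small groups, and in this assay the change from cyclopropyl to methyl reads a number 0.30 log units lower from compound 3 to compound 4 (within the scatter) and so does not clear the scatter. Among the compounds shown here, the change from ethyl to methyl reads a number 0.40 log units lower from compound 2 to compound 4 (beyond the scatter) and is the first step at this nitrogen to clear the scatter, though only modestly. Compound 3 stays within the scatter of both compound 2 and compound 4, so only compound 2 and compound 4 separate, and the three groups give no full order. Nothing measured here explains these numbers.

On these data alone, whether the amide hydrogen, a longer chain or a chain bearing a carboxylic acid at this nitrogen would stay near these numbers remains open. Also open, as far as these compounds go, is whether the ethyl to methyl step would hold on the core of compound 1.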